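Removing One Methoxy Group From a Weakly Cytotoxic Ketone

The source may report more compounds than this note shows. Statements on the series, on what has been measured and on what is new or still open speak of the compounds shown alone.

Of the compounds shown here, three with a shared core have been tested. In a functional assay on WRL68 cells (Homo sapiens) for cytotoxicity, read by MTT assay, with a stated time of 24 h (on this read-out lower numbers stand for stronger inhibition and higher numbers for weaker inhibition), compound 1 `COc1cc(C2C/C(=N\O)c3cc(OC)c(OC)c(OC)c32)cc(OC)c1OC` gives 223000 nM. Compound 3 `COc1cc(OC)c(C2CC(=O)c3cc(OC)c(OC)c(OC)c32)c(OC)c1` gives 22 nM in this assay, a result far stronger than that of compound 1. Compound 2 `COc1cccc(C2CC(=O)c3cc(OC)c(OC)c(OC)c32)c1` reaches only a limit of the assay, >= 250000 nM in this assay, so its exact potency is not known. Compound 2 is the one that sits at the limit of >= 250000 nM in this assay, at which 1 of the 3 values shown sits.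

Compound 4 `COc1cc2c(c(OC)c1OC)C(c1ccccc1)CC2=O` differs from compound 2 by hydrogen in place of methoxy on an aromatic carbon. Within the data shown here, no measured pair shows what such a change does here. Because compound 2 already stands at >= 250000 nM, the step of a number no higher from compound 2 to compound 4 (the limit leaves the size open) is expected to bring no change beyond the scatter. Compound 4 is therefore estimated at 250000 nM, between 100000 nM and 600000 nM, with a fair chance that the assay again reports only a limit.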

Compound 4, half-maximal inhibitory concentration: >= 250000 nM
Compound 4: only a limit was reported; the forecaster's own chance of this, stated with the estimate: 60%; the middle value sits exactly at the limit.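

Among these compounds, compound 2 and compound 4 each reach only a limit in this assay, so no step between them can be read. The compounds shown leave open whether going from 3-methoxyphenyl to phenyl changes potency at all.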